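Selenium for sulfur on the shared core of compound 3

The compounds below may be only part of what the source reports. "The series", "measured", "known", "first", "only" and "open" are said of these compounds alone.

Three compounds stand in an ADME assay on 184B5 cells (Homo sapiens) for cytotoxicity, read by MTT assay, with a stated time of 72 h (a lower number here means a stronger inhibitor of growth, a higher number a weaker inhibitor of growth), so far. Compound 1 `COc1ccc(CNc2nc([SeH])nc3ccccc23)cc1` gives only a limit of the assay, > 100000 nM. Compound 3 `Sc1nc(NCc2ccccc2)c2ccccc2n1` likewise gives only a limit, > 100000 nM. For compound 2 `C[Se]c1nc([Se]C)c2cccnc2n1` no result is reported, "not determined" (no result reported). Among the measured compounds shown here, compound 3 thus stands at the edge of what this assay reports, with no number of its own; the one other value shown is a limit as well, and the remaining entry carries no number.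

Compound 4 `[SeH]c1nc(NCc2ccccc2)c2ccccc2n1` is the next member to be measured in this assay . It differs from compound 3 by one selenium atom in place of one sulfur atom, on an aromatic carbon. For the measured compounds named here, no measured step between any two compounds here is known, so the size of the change cannot be read from the series. The step from compound 3 to compound 4 is expected to be none beyond the scatter, since the limit of > 100000 nM in this assay, at which 2 of the 3 values shown sit, marks where both numbered values sit. Compound 4 is therefore expected to give 100000 nM, within 40000 nM to 300000 nM, which means an expected step of a number no higher from compound 3 to compound 4 (the limit leaves the size open).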

Compound 4, concentration for total growth inhibition: 63600 nM
Compound 4: middle estimate off by 1.6-fold (0.20 log units), on the high side; measured number inside the range.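

In this assay, compound 4 gives this series its first reading that is a number and not a limit, 63600 nM, while the other readings stay at the edge of the assay: the limit of > 100000 nM in this assay, at which 2 of the 4 values shown sit.
One selenium atom in place of one sulfur atom on this aromatic carbon gives an at least 1.5-fold lower number from compound 3 to compound 4 (0.19 log units; that floor lies within the scatter), so the change has only a floor and no measured size. Hydrogen in place of methoxy on an aromatic carbon, on the selenium-bearing core, gives an at least 1.5-fold lower number from compound 1 to compound 4 (0.19 log units; that floor lies within the scatter), which is likewise only a floor.

The compounds shown leave open how far either step extends past its floor. They also leave open how an amine or a carboxylic acid would read on the aromatic carbon that carries the selenium atom in compound 4.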